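The source may report more compounds than this note shows. Statements on the series, on what has been measured and on what is new or still open speak of the compounds shown alone.

Three compounds share one core and differ in a saturated chain attached to it. For the measured compounds named here, in a functional assay on SK-OV-3 cells (Homo sapiens) for cytotoxicity, read by MTT assay, with a stated time of 24 h (on this read-out higher numbers stand for weaker inhibition and lower numbers for stronger inhibition), compound 1 `CCCCCCCC(=O)Nc1nnc(S[C@@H]2O[C@H](CO)[C@H](O)[C@H](O)[C@H]2O)s1` gives 56000 nM and so supplies the only firm number in the set. Compound 2 `CCCCCC(=O)Nc1nnc(S[C@@H]2O[C@H](CO)[C@H](O)[C@H](O)[C@H]2O)s1` is reported as "not active" (no number reported) in this assay and therefore has no single number to serve as a starting point. The compound still to be measured is compound 3 `CCCCCCCCCCCCCCCC(=O)Nc1nnc(S[C@@H]2O[C@H](CO)[C@H](O)[C@H](O)[C@H]2O)s1` and the structural change leading to it from compound 2 is decyl in place of hydrogen on a saturated chain carbon, five bonds along the chain from a carbonyl carbon with the core untouched: decyl in place of hydrogen on a saturated chain carbon, five bonds along the chain from a carbonyl carbon. Going by the values given here, no measured step exists to guide the size of this change, so any expectation is loose. The expected direction in this assay is towards stronger inhibition, with a real number replacing the absence of one. That number is expected to be modest and to lie in the same region as compound 1 at 56000 nM, although compound 3 may also yield no number at all. For compound 3 the estimated value is 30000 nM with an expected range of 8000 nM to 100000 nM in this test.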

Compound 3, half-maximal inhibitory concentration: "not active" (no number reported)
The entry for compound 3 holds no number; the estimate stays without a comparison.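

Compound 2 and compound 3 are both reported without a number in this assay, so no new step can be read between them. Left open is how the length of the saturated chain relates to strength of inhibition, with compound 1 at 56000 nM as the only firm number. Nothing available here bears on this result.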